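Trifluoromethyl in place of fluoro on compound 2

The source may hold more compounds than are shown below. What is called first, only, known or untested is meant among the compounds shown, and "the series" means these compounds.

In an ADME assay on L6 cells (Rattus norvegicus) for cytotoxicity, read by resazurin assay, with a stated time of 72 h (a lower number here means a stronger inhibitor, a higher number a weaker inhibitor), compound 1 (`Cc1ccc(C(O)(c2ccc(Cl)cc2)c2cccnc2)cc1`) gives 61000 nM and compound 2 (`OC(c1ccc(Cl)cc1)(c1cccnc1)c1cccc(F)c1`) gives 66000 nM, so the two stand within the scatter of each other. Compound 3 (`OC(c1ccc(Cl)cc1)(c1cccnc1)c1cccc(C(F)(F)F)c1`) carries trifluoromethyl in place of fluoro on an aromatic carbon. Among the compounds with values here, the only measured step, a 1.1-fold higher number from compound 1 to compound 2 (0.03 log units; within the scatter), brought in the 3-fluorophenyl that is changed here, and it offers no sign of a large shift. The estimated step is a 1.2-fold lower number from compound 2 to compound 3 (0.08 log units; within the scatter), which means none beyond the scatter is expected. For compound 3 the expected value is 55000 nM, with an estimated range of 25000 nM to 110000 nM.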

Compound 3, half-maximal inhibitory concentration: 60400 nM
Compound 3: the middle estimate sits 1.1-fold (0.04 log units) below what was measured, and the stated range covers the measured number.
By their numbers in this assay, from the lowest: compounds 3, 1 and 2 (each within the scatter of the next).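

In this assay the step (a 1.1-fold lower number from compound 2 to compound 3 (0.04 log units; within the scatter)) shows that trifluoromethyl can replace fluoro on this aromatic carbon, meta to a large group, without a shift beyond the scatter. The earlier step changed the whole aryl group, whereas this one changes only the group on that carbon, and the number still holds within the scatter. No other measurement bears on this result. On these data alone, whether an amine or a carboxylic acid on the same aromatic carbon would also stay within the scatter remains open.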